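This account rests on a few compounds, and the source may have more. Where it says the series, first, only, none or still open, it means among the compounds named here.

The measured compounds and their values in a physicochemical assay for acid dissociation, are:

compound 1, `FC(F)(F)c1ccc(-c2ccc3c(NCCCNCc4ccco4)ccnc3c2)cc1`: 9.47
compound 2, `COc1ccc(F)cc1CNCCCNc1ccnc2cc(C3CCCCC3)ccc12`: 9.47
compound 3, `COc1cccc(Oc2ccc3c(NCCCNCc4cc(F)ccc4OC)ccnc3c2)c1`: 9.28

In this assay compound 1 gives 9.47, the same number at the digits shown as compound 2, and compound 3 lies within the scatter of both. The three compounds share a core and differ only in the group carried on one aromatic carbon of that core.

The step to compound 4, `CN(C)c1cccc(Oc2ccc3c(NCCCNCc4ccco4)ccnc3c2)c1`, changes that same place: 3-(dimethylamino)phenoxy in place of 4-(trifluoromethyl)phenyl on an aromatic carbon. For the measured compounds named here, only one measured step bears on it. Going from compound 2 to compound 3 also replaces a carbon-linked group with an aryloxy group at this position, and that step was a number 0.19 log units lower from compound 2 to compound 3 (within the scatter). The proton that is being measured sits far from the exchanged group in every compound, and nothing in the three numbers shows this position influencing this assay beyond the scatter.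

Compound 4 is therefore expected to give a number close to that of compound 1, with a step of a number 0.07 log units lower from compound 1 to compound 4 (within the scatter) that is not expected to exceed the scatter. The estimate for compound 4 in this assay is 9.4, expected to fall between 9 and 9.8.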

Compound 4, acid dissociation constant: 9.28
For compound 4 the middle estimate is 0.12 log units above the measured one; low and high end bracket the measured number.
By their numbers in this assay, from the lowest: compounds 3, 4, 1 and 2 (each within the scatter of the next).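

In this assay, putting 3-(dimethylamino)phenoxy in place of 4-(trifluoromethyl)phenyl on this aromatic carbon gives a number 0.19 log units lower from compound 1 to compound 4 (within the scatter), so a group with 2 hydrogen-bond acceptors, entering where the leaving group has 0, still leaves the read-out within the scatter. The earlier step at this place, a number 0.19 log units lower from compound 2 to compound 3 (within the scatter), was read on a different side chain, so compound 1 and compound 4 carry the observation over to a second side chain: in both pairs an aryloxy group replaces a carbon-linked group with no step beyond the scatter. For the compounds shown here, this is also the first step at this place in which the entering group carries an amine nitrogen, and it too stays within the scatter.

It remains open whether a carboxylic acid or an aminomethyl group on this same aromatic carbon would also stay within the scatter in this assay, since every group shown here leaves the number where it was. No other measurement accompanies these values to explain why this position has so little bearing on the read-out.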